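The compounds below may be only part of what the source reports. "The series", "measured", "known", "first", "only" and "open" are said of these compounds alone.

Measured in a functional assay on HeLa cells (Homo sapiens) for inhibition, read by MTT assay, with a stated time of 48 h; on this read-out higher numbers stand for weaker inhibition and lower numbers for stronger inhibition:
- compound 1 `Oc1ccc(C(c2c[nH]c3ccc(Br)cc23)c2c[nH]c3ccc(Br)cc23)cc1`: 4000 nM
- compound 2 `COc1ccc(C(c2c[nH]c3ccc(Br)cc23)c2c[nH]c3ccc(Br)cc23)cc1OC`: 6100 nM

Among the compounds with values here, compound 2, at 6100 nM, cannot be told apart from compound 1, the only other measured compound. Within the data shown here, the single measured step is a 1.5-fold higher number from compound 1 to compound 2 (0.18 log units; within the scatter). That step exchanged 4-hydroxyphenyl for 3,4-dimethoxyphenyl on a saturated chain carbon bound to two aromatic carbons.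

Compound 3 `CN(C)c1ccc(C(c2c[nH]c3ccc(Br)cc23)c2c[nH]c3ccc(Br)cc23)cc1` changes the same place, with 4-(dimethylamino)phenyl in place of 3,4-dimethoxyphenyl (4-(dimethylamino)phenyl in place of 3,4-dimethoxyphenyl on a saturated chain carbon bound to two aromatic carbons). Among the measured compounds shown here, the one step that bears on this change stayed within the scatter, so no step beyond the scatter is expected in this assay. Neither measured compound carries the entering group, however, so this rests on thin evidence and the range is kept wide.

The expected change is a 1.3-fold lower number from compound 2 to compound 3 (0.10 log units; within the scatter). Compound 3 is estimated at 4800 nM, with an expected range from 1800 nM to 12000 nM.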

Compound 3, half-maximal inhibitory concentration: 12800 nM
Compound 3: middle estimate off by 2.7-fold (0.43 log units), on the low side; measured number outside the range, above it.
By their numbers in this assay, from the lowest: compounds 1 and 2 (each within the scatter of the next); then compound 3.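

In this assay, within the data shown here, the position on the saturated chain carbon bound to two aromatic carbons proves sensitive to the group it carries: 4-(dimethylamino)phenyl in place of 3,4-dimethoxyphenyl gives a 2.1-fold higher number from compound 2 to compound 3 (0.32 log units; beyond the scatter) and is the first step here to pass beyond the scatter, though only modestly. Dimethylamino in place of hydroxy on an aromatic carbon gives a 3.2-fold higher number from compound 1 to compound 3 (0.51 log units; beyond the scatter) and is also modest, so compound 3 stands apart from compound 1 and compound 2, which remain within the scatter of each other. Nothing available here accounts for the higher number.

Dimethylamino is the only nitrogen-bearing group on this ring, so it remains open whether the step belongs to that group alone or extends to other amines. An unsubstituted amine or a morpholine in its place would address this, and a carboxylic acid would extend the comparison further.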